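Swapping an Ethyl Sulfonamide for a Difluorophenyl One

The source may hold more compounds than are shown below. What is called first, only, known or untested is meant among the compounds shown, and "the series" means these compounds.

Of the compounds shown here, three built on one shared core have been tested in a functional assay on MCF7 cells (Homo sapiens) for cytotoxicity, read by sulforhodamine B assay, with a stated time of 72 h; on this read-out lower numbers stand for stronger inhibition and higher numbers for weaker inhibition. Compound 1 `CCS(=O)(=O)Nc1cc(-c2ccc3ncnc(Nc4ccc(F)cc4)c3c2)cnc1OC` gives 6510 nM. Compound 2 `CCS(=O)(=O)Nc1cc(-c2ccc3ncnc(Nc4cccc(C(=O)OC)c4)c3c2)cnc1OC` gives 10100 nM. Compound 3 `CCS(=O)(=O)Nc1cc(-c2ccc3ncnc(Nc4ccc(C(=O)OC)c(OC)c4)c3c2)cnc1OC` gives 10900 nM. The steps among them, a 1.6-fold higher number from compound 1 to compound 2 (0.19 log units; within the scatter), a 1.7-fold higher number from compound 1 to compound 3 (0.22 log units; within the scatter) and a 1.1-fold higher number from compound 2 to compound 3 (0.03 log units; within the scatter), all lie within the scatter, so compound 2 stands at the second highest number of the three without being set apart from either of the others.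

Compound 4 `COC(=O)c1cccc(Nc2ncnc3ccc(-c4cnc(OC)c(NS(=O)(=O)c5ccc(F)cc5F)c4)cc23)c1` has not yet been measured. It differs from compound 2 in one place: 2,4-difluorophenyl in place of ethyl on a sulfonyl sulfur. For the measured compounds named here, none of the measured steps touches this part of the molecule; each of them alters the group on the nitrogen on the aromatic ring instead, and each stayed within the scatter. Going by the values given here, no measured step therefore bears directly on this change, and nothing in the numbers so far points to a shift in either direction. The step from compound 2 to compound 4 is expected to be a 1.0-fold lower number from compound 2 to compound 4 (0.00 log units; within the scatter). Compound 4 is accordingly estimated at 10000 nM, with a range from 4000 nM to 25000 nM.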

Compound 4, half-maximal inhibitory concentration: 22400 nM
Compound 4: middle estimate off by 2.2-fold (0.35 log units), on the low side; measured number inside the range.
By their numbers in this assay, from the lowest: compounds 1, 2 and 3 (each within the scatter of the next); then compound 4.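

For the compounds shown here, the earlier compounds changed only the group on the nitrogen on an aromatic ring, so this is the first view of the sulfonyl sulfur, and in this assay this position does respond: 2,4-difluorophenyl in place of ethyl gives a 2.2-fold higher number from compound 2 to compound 4 (0.35 log units; beyond the scatter). Going by these compounds alone, since a higher number stands for weaker inhibition here, the group with the six-membered aromatic ring costs a modest amount of inhibition, and this is the first step in the set to go beyond the scatter. No measurement here explains why the change acts in this direction.

One step cannot tell whether the ring itself or its two fluorines account for the shift, and plain phenyl, methyl or a longer chain such as propyl on the sulfonyl sulfur would help separate these. As far as these compounds go, it also remains open whether the same swap would act alike with 4-fluorophenyl on the nitrogen, as in compound 1.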